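Pyrazole N-aryl swap: bromophenyl to methylphenyl

The compounds below may be only part of what the source reports. "The series", "measured", "known", "first", "only" and "open" are said of these compounds alone.

The series was read in a functional assay on DLD-1 cells (Homo sapiens) for cytotoxicity, read by colorimetric assay and MTT assay, with a stated time of 3 days, tested at 20 uM; on this read-out higher numbers stand for a weaker effect at the one concentration tested and lower numbers for a stronger effect. Compound 1 `O=C1COc2ccc(-c3[nH]c(-c4ccc(C(F)(F)F)cc4)nc3-c3ccccc3)cc2N1` gives 12.1%, compound 3 `O=C1COc2ccc(-c3[nH]c(-c4ccccc4)nc3-c3ccccc3)cc2N1` gives 47.3% and compound 2 `O=C1COc2ccc(-c3nn(-c4ccc(Br)cc4)cc3-c3ccccc3)cc2N1` gives 54.2%. Compound 2 thus stands highest of the three numbers shown; its nearest neighbour is compound 3, whose value lies within the scatter, while compound 1 lies farthest away, beyond the scatter. Among the compounds with values here, the only step between measured compounds that differ in one place is a number 35.2 percentage points higher from compound 1 to compound 3 (beyond the scatter), a large change that follows from a hydrogen in place of trifluoromethyl on an aromatic carbon.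

Compound 4 `Cc1ccccc1-n1cc(-c2ccccc2)c(-c2ccc3c(c2)NC(=O)CO3)n1` is not yet measured. Set against compound 2 it shows (2-methylphenyl in place of 4-bromophenyl on an aromatic nitrogen), a change on an aromatic nitrogen of a five-membered aromatic ring with 2 nitrogen. Within the data shown here, no measured step touches that position, and the one measured step concerns another place on a different core, so it gives no direct guide to this change. In this assay compound 4 is therefore expected to stay near compound 2, with a step of a number 0.8 percentage points higher from compound 2 to compound 4 (within the scatter) that is not expected to exceed the scatter. The estimate for compound 4 in this assay is 55%, with a range from 30% to 80%.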

Compound 4, a percentage reported as activity, at one concentration (the size of the read-out at that concentration, not a potency): 62.9%
Compound 4: the middle estimate sits 7.9 percentage points below what was measured, and the stated range covers the measured number.
By their numbers in this assay, from the lowest: compound 1; then compounds 3, 2 and 4 (each within the scatter of the next, the first and the last beyond it).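

Within the data shown here, this is the only measured step at the aromatic nitrogen of the five-membered ring, and in this assay 2-methylphenyl in place of 4-bromophenyl gives a number 8.7 percentage points higher from compound 2 to compound 4 (within the scatter), so the two aryl groups cannot be told apart on this read-out at the one concentration tested. The exchange swaps bromine for a methyl carbon, while the count stays at 7 heavy atoms, with one six-membered aromatic ring of carbon only and no hydrogen-bond donors or acceptors. Nothing available explains why the read-out stays within the scatter across this exchange.

Among these compounds, the single step joins a change of substituent with a change of its place on the phenyl ring, so a 4-methylphenyl or a 2-bromophenyl group would be needed to read the two apart. On these data alone, what an amine or a carboxylic acid on that phenyl ring, or a longer chain on the nitrogen in place of the aryl group, would do remains open, as does whether trifluoromethyl would matter here as it does on the core of compound 1, where the step is a number 35.2 percentage points higher from compound 1 to compound 3 (beyond the scatter).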